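A Third Chlorine on the Benzyl Ring

The source may hold more compounds than are shown below. What is called first, only, known or untested is meant among the compounds shown, and "the series" means these compounds.

Compound 1 `N[C@]1(C(=O)O)[C@H]2[C@@H](C[C@H]1OCc1cccc(F)c1F)[C@]2(F)C(=O)O` gives 4.25 nM in an assay on CHO cells for binding affinity to metabotropic glutamate receptor 2 (Rattus norvegicus); on this read-out higher numbers stand for weaker inhibition and lower numbers for stronger inhibition.
Compound 2 `N[C@]1(C(=O)O)[C@H]2[C@@H](C[C@H]1OCc1cc(Cl)cc(Cl)c1)[C@]2(F)C(=O)O` gives 5.61 nM in this assay.

Both compounds share the same amino acid core and differ only in the aromatic ring attached through the ether linker. On the two numbers measured, compound 2 shows the highest number, and its nearest neighbour is compound 1; the step of a 1.3-fold higher number from compound 1 to compound 2 (0.12 log units; within the scatter) lies within the scatter, so the two compounds cannot be told apart on this read-out.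

Compound 3 `N[C@]1(C(=O)O)[C@H]2[C@@H](C[C@H]1OCc1cc(Cl)c(Cl)c(Cl)c1)[C@]2(F)C(=O)O` has not been measured yet. It differs from compound 2 by chloro in place of hydrogen on an aromatic carbon, ortho to two chloro groups and para to a large group, so the ring now carries three chloro groups instead of two.

Among the measured compounds shown here, the only measured step that bears on this change is the exchange of one halogenated ring for another, from compound 1 to compound 2, and that step stayed within the scatter. On this narrow base, no change beyond the scatter is expected for compound 3 in this assay, and the step of a 1.2-fold higher number from compound 2 to compound 3 (0.06 log units; within the scatter) is expected to be small. The estimate for compound 3 is therefore 6.5 nM, with a range from 2.5 nM to 17 nM.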

Compound 3, inhibition constant: 3.67 nM
Estimate against measurement, compound 3: 1.8-fold (0.25 log units) above, and the stated range covers the measured number.
By their numbers in this assay, from the lowest: compounds 3, 1 and 2 (each within the scatter of the next).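

Chloro in place of hydrogen on the aromatic carbon, ortho to two chloro groups and para to a large group, gives a 1.5-fold lower number from compound 2 to compound 3 (0.18 log units; within the scatter) in this assay, so at this carbon the read-out does not separate a chlorine from a hydrogen. The earlier step swapped one halogenated ring for another and altered several ring places at once, so it could not show what any single place contributes; this step changes just one place, adding a single heavy atom, and it also stays within the usual scatter of the measurement. No measurement is at hand that would explain this result.

The compounds shown leave open whether this carbon accepts only a halogen or would also carry a group of a quite different kind, such as an amine, a carboxylic acid or a longer chain like butyl. Since all three compounds lie within the scatter of one another in this assay, they also leave open which change on this ring, if any, would move the number beyond that scatter.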